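Benzyloxy in Place of Propoxy on the Shared Core

The compounds below may be only part of what the source reports. "The series", "measured", "known", "first", "only" and "open" are said of these compounds alone.

Compound 1 `COc1ccc(CSc2nc(C(C)(C)C)ccc2CNC(=O)C(C)c2ccc(NS(C)(=O)=O)c(F)c2)cc1`: 3.5 nM
Compound 2 `CCCOc1cc(C(C)(C)C)ccc1CNC(=O)C(C)c1ccc(NS(C)(=O)=O)c(F)c1`: 4.4 nM

In an assay on cells for antagonist activity at transient receptor potential cation channel subfamily V member 1 (Homo sapiens), read by FLIPR and calcium flux, with a stated time of 6 min (a lower number here means a stronger inhibitor, a higher number a weaker inhibitor), compound 1 gives 3.5 nM and compound 2 gives 4.4 nM; the two numbers lie within the usual scatter of each other, so neither stands apart. Compound 3 `CC(C(=O)NCc1ccc(C(C)(C)C)cc1OCc1ccccc1)c1ccc(NS(C)(=O)=O)c(F)c1` differs from compound 2 by phenyl in place of ethyl on a saturated chain carbon bound to an oxygen on an aromatic ring, that is, propoxy to benzyloxy. Going by the values given here, no measured pair shows this change, so its size is not known from the data. A step of a 1.3-fold lower number from compound 2 to compound 3 (0.10 log units; within the scatter) in this assay is expected, small and within the scatter. Compound 3 is estimated at 3.5 nM, with a range from 1.2 nM to 11 nM.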

Compound 3, inhibition constant: 2.9 nM
For compound 3 the middle estimate is 1.2-fold (0.08 log units) above the measured one; the range from low to high includes it.
By their numbers in this assay, from the lowest: compounds 3, 1 and 2 (each within the scatter of the next).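

In this assay, exchanging propoxy for benzyloxy gives a 1.5-fold lower number from compound 2 to compound 3 (0.18 log units; within the scatter). Going by these compounds alone, this is the first direct reading at this position: phenyl in place of ethyl on a saturated chain carbon bound to an oxygen on an aromatic ring leaves compound 3 within the scatter of compound 2, even though the group entering is larger and brings a six-membered aromatic ring. Nothing available explains why the number holds across this change. On these data alone, whether a longer chain, or an amine or carboxylic acid at the end of this chain, would be tolerated equally remains open.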